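Oxan-4-yl to (oxan-4-yl)methyl on the aromatic oxygen

A few compounds are considered here, and "the series" means these few. Any claim that something is new, unique, unknown or untested is made for them only; others in the source may bear on it.

Measured in a functional assay on SH-SY5Y cells (Homo sapiens) for antagonist activity, read by cAMP accumulation (a higher number here means a more potent compound, by a factor of ten per unit of this negative logarithm, a lower number a less potent compound), so far:
- compound 1 `CCCOc1ccc(Cc2ccc(NC3=NCCN3)cc2)cc1` gives 8.8
- compound 2 `COCCOc1ccc(Cc2ccc(NC3=NCCN3)cc2)cc1` gives 8
- compound 3 `c1cc(NC2=NCCN2)ccc1Cc1ccc(OC2CCOCC2)cc1` gives 8.4

Compound 3 holds the middle place of these three numbers. Compound 4 `c1cc(NC2=NCCN2)ccc1Cc1ccc(OCC2CCOCC2)cc1` is not yet measured. It differs from compound 3 by (oxan-4-yl)methyl in place of oxan-4-yl on an oxygen on an aromatic ring with (oxan-4-yl)methyl in place of oxan-4-yl on an oxygen on an aromatic ring. Among the measured compounds shown here, no measured step makes this exact change. The nearest guides are a number 0.40 log units lower from compound 1 to compound 3 (beyond the scatter) and a number 0.40 log units higher from compound 2 to compound 3 (beyond the scatter) at the same oxygen, along with a number 0.80 log units lower from compound 1 to compound 2 (beyond the scatter) on the chain there. All three are modest, so only a modest change at most is expected in this assay and no direction is favoured. The expected step of a number 0.10 log units lower from compound 3 to compound 4 (within the scatter) is none beyond the scatter. For compound 4 the estimated value is 8.3 with an expected range from 7.8 to 8.8 on this scale.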

Compound 4, negative logarithm of the antagonist equilibrium constant: 8.5
Estimate against measurement, compound 4: 0.20 log units below, within the range that was stated.
By their numbers in this assay, from the lowest: compound 2; then compounds 3, 4 and 1 (each within the scatter of the next, the first and the last beyond it).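

Swapping oxan-4-yl for (oxan-4-yl)methyl on the aromatic oxygen gives a number 0.10 log units higher from compound 3 to compound 4 (within the scatter) in this assay, so the ring can carry this added carbon without a change beyond the scatter. With the ring on that carbon, the comparison with the 2-methoxyethyl ether gives a number 0.50 log units higher from compound 2 to compound 4 (beyond the scatter) and the comparison with the propyl ether gives a number 0.30 log units lower from compound 1 to compound 4 (within the scatter) in this assay, whereas compound 3 stood beyond the scatter of compound 1.

From the compounds shown here alone, whether a longer link, such as 2-(oxan-4-yl)ethyl, or a ring amine, such as (piperidin-4-yl)methyl, would be accommodated remains open. Nothing available here explains these numbers.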